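Chain length on sulfur in a short series

A few compounds are considered here, and "the series" means these few. Any claim that something is new, unique, unknown or untested is made for them only; others in the source may bear on it.

compound 1 `CSC[C@H](NC(C)=O)C(=O)CCl`: 80800 nM
compound 2 `CCCCCSC[C@H](NC(C)=O)C(=O)CCl`: 5400 nM

Among the measured compounds shown here, in a functional assay on MOLT-3 cells (Homo sapiens) (a higher number here means a weaker inhibitor, a lower number a stronger inhibitor), compound 2 gives 5400 nM, the lowest of the two numbers so far. Compound 3 `CCCCCCCCCCSC[C@H](NC(C)=O)C(=O)CCl` extends the chain of compound 2: pentyl in place of hydrogen on a saturated chain carbon, five bonds along the chain from a sulfur. In words, this is pentyl in place of hydrogen on a saturated chain carbon, five bonds along the chain from a sulfur.

For the measured compounds named here, one measured step bears on this change: a 15-fold lower number from compound 1 to compound 2 (1.18 log units; beyond the scatter). It placed butyl in place of hydrogen on a saturated chain carbon bound to a sulfur, and it was large and beyond the scatter. A single step cannot show how far the direction carries, and two compounds make no pattern. The working expectation is a further fall in the number, by a somewhat smaller step, with wide uncertainty. The expected change is a 5.4-fold lower number from compound 2 to compound 3 (0.73 log units; beyond the scatter). Compound 3 is estimated at 1000 nM, with an expected range from 200 nM to 4500 nM.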

Compound 3, half-maximal inhibitory concentration: 3400 nM
For compound 3 the middle estimate is 3.4-fold (0.53 log units) below the measured one; low and high end bracket the measured number.
By their numbers in this assay, from the lowest: compounds 3 and 2 (each within the scatter of the next); then compound 1.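

In this assay, the step with pentyl in place of hydrogen on a saturated chain carbon, five bonds along the chain from a sulfur, is a 1.6-fold lower number from compound 2 to compound 3 (0.20 log units; within the scatter), whereas the earlier extension gave a 15-fold lower number from compound 1 to compound 2 (1.18 log units; beyond the scatter). Among the compounds shown here, the large step seen on the first extension is therefore not repeated on this further extension, and compound 2 and compound 3 cannot be told apart in this assay, so the series so far shows a clear difference only for the first extension. No measurement on hand speaks to what lies behind this flat reading, and none goes beyond the numbers of the assay itself.

Still open, from the compounds shown here alone, is whether the flat reading holds for chains of other lengths: an octyl chain in the same place would test the range already covered, and a dodecyl chain would test whether a longer chain leaves the number unchanged or moves it in either direction. Also open is how the chain responds to a group at its far end, such as an amine or a carboxylic acid, since every chain shown here is plain saturated carbon.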